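Notes on plasma binding in a small series

The compounds below may be only part of what the source reports. "The series", "measured", "known", "first", "only" and "open" are said of these compounds alone.

Measured in an ADME assay on a cell-free system (plasma, Homo sapiens) for protein binding, so far:
Compound 1 `Cc1cn2cc(-c3cc4ccc(N5CCN(C)CC5)cc4oc3=O)nc2cn1` gives 97% 
Compound 2 `CCN1CCN(c2ccc3cc(-c4cn5cc(C)nc(C)c5n4)c(=O)oc3c2)C[C@@H]1C` gives 96% 

Compound 2 lies within the scatter of compound 1 on the unbound fraction, so this assay does not separate the two measured compounds, and both are largely bound. Next in line is compound 3 `Cc1cn2cc(-c3cc4ccc(N5CCN(C)CC5)cc4oc3=O)nc2c(C)n1` with this change: 4-methylpiperazin-1-yl in place of 4-ethyl-3-methylpiperazin-1-yl on an aromatic carbon in which 4-methylpiperazin-1-yl stands in place of 4-ethyl-3-methylpiperazin-1-yl on an aromatic carbon. Among the measured compounds shown here, no measured step isolates this change. With compound 2 at 96% and compound 1 at 97% within the scatter of each other, no shift beyond the scatter is expected. The estimated step a 1.1-fold lower unbound fraction from compound 2 to compound 3 (0.06 log units; within the scatter) is expected to stay within the scatter. Compound 3 is expected at 96.5% within an estimated range of 93% to 98.5% when measured.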

Compound 3, plasma protein binding: 97%
Beside the measured number, compound 3's estimate is 1.2-fold (0.07 log units) (unbound fraction) above it, within the range that was stated.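

Within this assay, 4-methylpiperazin-1-yl in place of 4-ethyl-3-methylpiperazin-1-yl on an aromatic carbon now has a reading of its own (a 1.3-fold lower unbound fraction from compound 2 to compound 3 (0.12 log units; within the scatter)), so removing this substitution from the piperazine does not separate the two compounds. Methyl in place of hydrogen on an aromatic carbon gives a second reading, at a different place on the shared core (no change at the digits printed from compound 1 to compound 3 (within the scatter)), and this change does not separate its pair either. No available measurement bears on what lies behind these readings.

Open, going by these compounds, is whether a carboxylic acid or a morpholine ring in place of 4-methylpiperazin-1-yl on that aromatic carbon would give a step beyond the scatter in this assay. Also open, on these data alone, is whether a longer chain in place of the added methyl would do so.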